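The compounds below may be only part of what the source reports. "The series", "measured", "known", "first", "only" and "open" are said of these compounds alone.

Measured in a functional assay (Gallus gallus) for inhibition; a higher number here means a weaker inhibitor, a lower number a stronger inhibitor:
Compound 1 `CC(=O)NC1C(OC(=O)CNS(=O)(=O)c2cccc3c(N(C)C)cccc23)CC(OCCCCCCC(=O)NCc2cccc3ccccc23)(C(=O)O)OC1[C@@H](O)[C@H](O)CO`: 3000 nM.
Compound 2 `C=CC(=O)NOCCCOCCCCOC1(C(N)=O)CC(O)C(NC(C)=O)C([C@@H](O)[C@H](O)CO)O1`: > 600000 nM, a limit of the assay and not a number.

From the compounds shown here alone, compound 2 sits at the limit of > 600000 nM in this assay, at which 1 of the 2 values shown sits, so its true value is unknown and only the weak end of the scale is defined. The values show compound 2 as the weaker of the two measured compounds. Going by the values given here, no step between measured compounds connects them, so compound 1 gives little guidance on the next change.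

Compound 3 `C=CC(=O)NOCCCOCCCCOC1(C(C)=O)CC(O)C(NC(C)=O)C([C@@H](O)[C@H](O)CO)O1` keeps the rest of compound 2 and makes one change: methyl in place of amino on a carbonyl carbon. This puts methyl in place of amino on a carbonyl carbon, which also reads as carbamoyl to acetyl. Among the compounds with values here, no measured pair tests this swap, so no direction can be argued from the data. In this assay, no change beyond the usual scatter is expected, and compound 3 is expected to remain a very weak inhibitor, quite possibly reported only as a limit.

The expected change is a step that the limit leaves unreadable from compound 2 to compound 3. The estimate for compound 3 is 700000 nM, with an expected range of 150000 nM to 2000000 nM.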

Compound 3, inhibition constant: > 600000 nM
Compound 3: only a limit was reported; the forecaster's own chance of this, stated with the estimate: 70%; the middle value lies beyond the limit too.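

No step can be read between compound 2 and compound 3 in this assay, because both values are limits of the assay and not numbers: the limit of > 600000 nM in this assay, at which 2 of the 3 values shown sit.

The compounds shown leave open how far either compound lies beyond that limit, and whether methyl in place of amino on a carbonyl carbon alters inhibition at all.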